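From cyclopentyloxy to iodo in compound 4

The compounds below may be only part of what the source reports. "The series", "measured", "known", "first", "only" and "open" are said of these compounds alone.

compound 1 `O=C(CCl)NC(=O)Nc1ccc(OC2CCCC2)cc1` gives 3900 nM
compound 2 `O=C(CCl)NC(=O)Nc1ccc(OC2CCCCCC2)cc1` gives 3600 nM
compound 3 `O=C(CCl)NC(=O)Nc1ccc(OCc2ccccc2)cc1` gives 4600 nM

These values come from a functional assay on MCF7 cells (Homo sapiens) for inhibition, read by sulforhodamine B assay, with a stated time of 48 h (on this read-out lower numbers stand for stronger inhibition of growth and higher numbers for weaker inhibition of growth), and compound 1 stands within the scatter of both other compounds, so the three form one group. Compound 4 `O=C(CCl)NC(=O)Nc1ccc(I)cc1` carries iodo in place of cyclopentyloxy on an aromatic carbon. The measured steps are all small: a 1.1-fold lower number from compound 1 to compound 2 (0.03 log units; within the scatter) and a 1.2-fold higher number from compound 1 to compound 3 (0.07 log units; within the scatter) and a 1.3-fold higher number from compound 2 to compound 3 (0.11 log units; within the scatter) stay within the scatter. Within the data shown here, each of them swaps one group on an oxygen for another, and no measured compound carries iodo, so they bear on this change only loosely. A step within the scatter is therefore expected, with a slight lean toward weaker inhibition and no firm direction. The expected size is a 1.3-fold higher number from compound 1 to compound 4 (0.11 log units; within the scatter) as a rough estimate. For compound 4 the estimate is 5000 nM with an expected range from 2000 nM to 12000 nM in this wide band.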

Compound 4, concentration for 50% growth inhibition: 6800 nM
The estimate for compound 4 lay 1.4-fold (0.13 log units) below the measured number; low and high end bracket the measured number.
By their numbers in this assay, from the lowest: compounds 2, 1, 3 and 4 (each within the scatter of the next).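

In this assay, iodo in place of cyclopentyloxy on the aromatic carbon gives a 1.7-fold higher number from compound 1 to compound 4 (0.24 log units; within the scatter). The earlier compounds shown here only exchanged the group on the oxygen, whereas this change removes the oxygen and the ring together, and compound 4 still stays within the scatter of compound 1, so neither is needed at this position for growth inhibition in this small set. Nothing available explains this result. As far as these compounds go, whether an amine, a carboxylic acid or a longer chain at this place would stay in the same band remains open, as does whether any group here gives a step beyond the scatter.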